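The source may hold more compounds than are shown below. What is called first, only, known or untested is meant among the compounds shown, and "the series" means these compounds.

Three analogues of one core have numbers in a functional assay on SK-MEL-28 cells (Homo sapiens) for antiproliferative activity, with a stated time of 48 h; a lower number here means a stronger inhibitor of growth, a higher number a weaker inhibitor of growth. Compound 1 `Cc1cc(O)c(C2=NN(c3ccc(S(N)(=O)=O)cc3)C(c3ccccc3O)C2)cc1Cl` gives 13500 nM; compound 2 `Cc1cc(O)c(C2=NN(c3ccc(S(N)(=O)=O)cc3)C(c3ccccc3Cl)C2)cc1Cl` gives 12300 nM; compound 3 `Cc1cc(O)c(C2=NN(c3ccc(S(N)(=O)=O)cc3)C(/C=C/c3ccccc3)C2)cc1Cl` gives 23800 nM. Compound 3 has the highest of the three numbers, yet its gaps to compound 1 and to compound 2 both stay within the scatter. Compound 4 `COc1ccc(C2CC(c3cc(Cl)c(C)cc3O)=NN2c2ccc(S(N)(=O)=O)cc2)cc1OC` is not yet measured; it differs from compound 3 by 3,4-dimethoxyphenyl in place of 2-phenylethenyl on a saturated ring carbon. Among the compounds with values here, the steps that bear on this change run the other way: a 1.8-fold higher number from compound 1 to compound 3 (0.25 log units; within the scatter) and a 1.9-fold higher number from compound 2 to compound 3 (0.29 log units; within the scatter), both within the scatter, while a 1.1-fold lower number from compound 1 to compound 2 (0.04 log units; within the scatter) shows that a change within the aryl group itself also stays within the scatter. An aryl group in place of 2-phenylethenyl is therefore expected to give at most a small move toward lower numbers, a 1.7-fold lower number from compound 3 to compound 4 (0.23 log units; within the scatter). Compound 4 is estimated at 14000 nM in this assay, within 6000 nM to 32000 nM.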

Compound 4, concentration for total growth inhibition: 17700 nM
Beside the measured number, compound 4's estimate is 1.3-fold (0.10 log units) below it, and the stated range covers the measured number.
By their numbers in this assay, from the lowest: compounds 2, 1, 4 and 3 (each within the scatter of the next).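

In this assay, placing 3,4-dimethoxyphenyl on the saturated ring carbon next to the ring nitrogen brings in 2 hydrogen-bond acceptors, yet all three new steps stay within the scatter (a 1.3-fold lower number from compound 3 to compound 4 (0.13 log units; within the scatter)), (a 1.4-fold higher number from compound 2 to compound 4 (0.16 log units; within the scatter)) and (a 1.3-fold higher number from compound 1 to compound 4 (0.12 log units; within the scatter)). This position therefore now shows a flat response across four groups, including one with two methoxy substituents. No evidence on hand accounts for this flat response.

From the compounds shown here alone, whether an amine, a carboxylic acid or a longer alkyl chain on this carbon would move the number beyond the scatter remains open. Also open, going by these compounds, is whether the response stays flat when the rest of the shared core changes.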